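The source may hold more compounds than are shown below. What is called first, only, known or untested is meant among the compounds shown, and "the series" means these compounds.

Compound 1 `O=C(NO)c1ccc(-c2ccc(CNCc3ccccc3Cl)cn2)s1`: 110 nM
Compound 2 `O=C(NO)c1ccc(-c2ccc(CNCc3ccc(Cl)cc3)cn2)s1`: 130 nM
Compound 3 `CN(Cc1ccccc1)Cc1ccc(-c2ccc(C(=O)NO)s2)nc1`: 150 nM

In a functional assay on MCF7 cells (Homo sapiens) for inhibition (a higher number here means a weaker inhibitor, a lower number a stronger inhibitor), compound 2 gives 130 nM, which lies within the scatter of the values of both compound 1 and compound 3. Compound 4 `O=C(NO)c1ccc(-c2ccc(CNCCOc3ccccc3)cn2)s1` has not yet been measured. It differs from compound 2 as follows: phenoxymethyl in place of 4-chlorophenyl on a saturated chain carbon bound to an amine nitrogen. Going by the values given here, only one measured step bears on this place, a 1.2-fold higher number from compound 1 to compound 2 (0.07 log units; within the scatter), and it exchanges 2-chlorophenyl for 4-chlorophenyl. Among the compounds with values here, no measured compound carries phenoxymethyl, so this evidence is limited and the range must stay wide. No shift beyond the scatter is expected in this assay, and the estimated change is a 1.1-fold lower number from compound 2 to compound 4 (0.03 log units; within the scatter). Compound 4 is expected at about 120 nM, with an estimated range of 50 nM to 280 nM.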

Compound 4, half-maximal inhibitory concentration: 110 nM
The estimate for compound 4 lay 1.1-fold (0.04 log units) above the measured number, and the stated range covers the measured number.
By their numbers in this assay, from the lowest: compounds 1, 4, 2 and 3 (each within the scatter of the next).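

Until now this place, on a saturated chain carbon bound to an amine nitrogen, had only shown an exchange between two chlorophenyl groups. In this assay, phenoxymethyl, which adds a hydrogen-bond acceptor and loses the chlorine, also stays within the scatter, with a 1.2-fold lower number from compound 2 to compound 4 (0.07 log units; within the scatter) and no change at the digits printed from compound 1 to compound 4 (within the scatter), so the change of group is not seen in this read-out. No available evidence bears on this result.

Every group shown here carries a six-membered aromatic ring of carbon only. Going by these compounds, whether a carboxylic acid or a simple amine at this place would hold the number in the same range remains open.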